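The source may hold more compounds than are shown below. What is called first, only, known or untested is meant among the compounds shown, and "the series" means these compounds.

Compound 3 `Clc1ccc(Oc2ccc3c(NCCCNCc4ccco4)ccnc3c2)cc1` is the starting point. For the measured compounds named here, in an ADME assay for permeability, using PAMPA, with a stated time of 30 min, at pH 7.4 (a higher number here means that the compound crosses the layer faster, a lower number that the compound crosses the layer more slowly), compound 3 gives 317 10^-6 cm/s, the highest of the three numbers measured so far. Compound 1 `COc1ccc(-c2ccc3c(NCCCNCc4ccco4)ccnc3c2)cc1` comes closest: in this assay compound 1 gives 237 10^-6 cm/s, so there is a 1.3-fold higher number from compound 1 to compound 3 (0.13 log units; within the scatter). Compound 2 `c1coc(CNCCCNc2ccnc3cc(CC4CCCCC4)ccc23)c1` lies furthest away: in this assay compound 2 gives 23 10^-6 cm/s, and there is a 14-fold higher number from compound 2 to compound 3 (1.14 log units; beyond the scatter).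

The next compound, compound 4 `N#Cc1ccc(Cc2ccc3c(NCCCNCc4ccco4)ccnc3c2)cc1`, differs from compound 3 in one place: 4-cyanobenzyl in place of 4-chlorophenoxy on an aromatic carbon.

Two kinds of measured step bear on this change. Exchanging one group that carries a six-membered aromatic ring of carbon only for another group of the same kind gave a 1.3-fold higher number from compound 1 to compound 3 (0.13 log units; within the scatter), within the scatter. Exchanging such a group for cyclohexylmethyl gave a 10-fold lower number from compound 1 to compound 2 (1.01 log units; beyond the scatter) and, in the other direction, a 14-fold higher number from compound 2 to compound 3 (1.14 log units; beyond the scatter), both large. Since 4-cyanobenzyl keeps a six-membered aromatic ring of carbon only, the first kind of step is the closer model, and no step beyond the scatter is expected in this assay, with at most a small drop. Compound 4 is therefore estimated at 200 10^-6 cm/s, with a range from 90 10^-6 cm/s to 380 10^-6 cm/s, which means an expected step of a 1.6-fold lower number from compound 3 to compound 4 (0.20 log units; within the scatter).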

Compound 4, apparent permeability: 23 10^-6 cm/s
Compound 4: the middle estimate sits 8.7-fold (0.94 log units) above what was measured; measured number outside the range, below it.
By their numbers in this assay, from the lowest: compounds 2 and 4 (each within the scatter of the next); then compounds 1 and 3 (each within the scatter of the next).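

In this assay, keeping a six-membered aromatic ring of carbon only at this position is no guarantee of a high number: the change to 4-cyanobenzyl gives a large step (a 14-fold lower number from compound 3 to compound 4 (1.14 log units; beyond the scatter)), and the comparison with the other compound carrying such a ring at this position is also large (a 10-fold lower number from compound 1 to compound 4 (1.01 log units; beyond the scatter)). The kind of ring matters little once a saturated chain carbon is bound to the aromatic carbon of the core: 4-cyanophenyl in place of cyclohexyl on that carbon leaves the number unchanged (no change at the digits printed from compound 2 to compound 4 (within the scatter)), so among these four compounds the two with that saturated carbon sit at the low end and the two without it at the high end, with none going against this. Nothing shown gives a reason for this pattern.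

Going from compound 3 to compound 4 alters both the atom linking the ring to the core and the group on that ring, so the drop cannot yet be assigned to either change alone. A 4-chlorobenzyl or a 4-cyanophenoxy group at the same place would separate the two.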